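The compounds below may be only part of what the source reports. "The series", "measured", "known", "first", "only" and "open" are said of these compounds alone.

Results so far in an ADME assay on RAW264.7 cells (Mus musculus) for cytotoxicity, read by MTT assay; a lower number here means a stronger inhibitor, a higher number a weaker inhibitor

Compound 1 (`Cc1ccc(C(=O)/C=C/C=C/c2ccccc2)s1`) gives > 100000 nM as a limit of the assay
Compound 2 (`COc1ccc(/C=C/C=C/C(=O)c2ccc(C)s2)cc1`) gives "not determined" (no result reported) as its entry
Compound 3 (`COc1ccc(/C=C/C=C/C(=O)c2cc(C)sc2C)cc1`) gives "not determined" (no result reported) as its entry

Compound 2 has no single number to stand on, since no result was reported for it, and the same is true of compound 3. For the measured compounds named here, the only other entry is the one for compound 1, and that entry is a limit and not a number.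

The next compound to be tested in this assay is compound 4 (`Cc1ccc(C(=O)/C=C/C=C/c2ccc(O)cc2)s1`) and it is the focus of this account. The structural change is hydrogen in place of methyl on an oxygen on an aromatic ring and it amounts to methoxy to hydroxy, with hydrogen in place of methyl on an oxygen on an aromatic ring.

Going by the values given here, no measured step between related compounds is available to size this change. The expectation is therefore of no step beyond the usual scatter in this assay and of no preferred direction. Among the compounds with values here, the only guide is the limit of > 100000 nM in this assay, at which 1 of the 3 values shown sits, and it comes from compound 1. On that basis weak inhibition is expected, in the upper part of the range the assay can report. For compound 4 the estimated value is 60000 nM with an expected range from 15000 nM to 100000 nM and a fair chance of a limit in place of a number.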

Compound 4, half-maximal inhibitory concentration: 28300 nM
For compound 4 the middle estimate is 2.1-fold (0.33 log units) above the measured one; the range from low to high includes it.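

Hydroxy in place of hydrogen on an aromatic carbon gives an at least 3.5-fold lower number from compound 1 to compound 4 (0.54 log units; beyond the scatter) in this assay, and this is the first change in the series whose direction can be read. It shows that this place on the aromatic ring is not silent in this assay, as a single added hydroxy moves the entry off the limit and onto a measured number, though that number still reflects weak inhibition. The step has only one firm end and its true size stays unknown, because compound 1 stands at a limit of the assay rather than at a number: the limit of > 100000 nM in this assay, at which 1 of the 4 values shown sits.

As far as these compounds go, the change from methoxy to hydroxy cannot be read, as compound 2 has no reported result, so it stays open whether the free hydroxy matters or whether any oxygen at this place would give the same shift. Also open, from the compounds shown here alone, is how an amine or a carboxylic acid on the same aromatic carbon would compare with hydroxy, and whether one hydroxy on a single compound pair says anything about other cores.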